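Sulfonyl sulfur substituent: compound 2 to compound 3

The source may report more compounds than this note shows. Statements on the series, on what has been measured and on what is new or still open speak of the compounds shown alone.

Measured in a functional assay on DLD-1 cells (Homo sapiens) for antiproliferative activity, read by CellTiter-Glo, with a stated time of 72 h; on this read-out higher numbers stand for weaker inhibition and lower numbers for stronger inhibition:
Compound 1 (`CC1CCN(C2CCN(S(=O)(=O)c3ccccc3Br)CC2)CC1`): 3 nM
Compound 2 (`CCc1ccc(S(=O)(=O)N2CCC(N3CCC(C)CC3)CC2)cc1`): > 5000 nM (a limit of the assay, not a number)

Compound 2 stands at the limit of > 5000 nM in this assay, at which 1 of the 2 values shown sits, and so carries no number. Among the measured compounds shown here, the only measured step, an at least 1600-fold higher number from compound 1 to compound 2 (3.22 log units; beyond the scatter), is large and beyond the scatter, with 4-ethylphenyl in place of 2-bromophenyl on a sulfonyl sulfur.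

Compound 3 (`CC1CCN(C2CCN(S(=O)(=O)c3ccc(Cl)cc3Cl)CC2)CC1`) has 2,4-dichlorophenyl in place of 4-ethylphenyl on a sulfonyl sulfur. It loses the 4-ethylphenyl of compound 2 and, like the 2-bromophenyl of compound 1, has a halogen-bearing phenyl. For the measured compounds named here, on the evidence of the single step of an at least 1600-fold higher number from compound 1 to compound 2 (3.22 log units; beyond the scatter), a large move to a lower number in this assay is expected, though one step is thin support. The expected step is an at least 250-fold lower number from compound 2 to compound 3 (2.39 log units; beyond the scatter) and is large. For compound 3 the estimated value is 20 nM, with an expected range of 3 nM to 300 nM.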

Compound 3, half-maximal inhibitory concentration: 1 nM
Compound 3: middle estimate off by 20-fold (1.30 log units), on the high side, and the stated range ends above it.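

In this assay, a low number at the sulfonyl sulfur is not tied to 2-bromophenyl alone: 2,4-dichlorophenyl in place of 4-ethylphenyl gives an at least 5000-fold lower number from compound 2 to compound 3 (3.69 log units; beyond the scatter). The value of compound 2 is a limit, not a number: the limit of > 5000 nM in this assay, at which 1 of the 3 values shown sits. The two halogen-bearing phenyl groups also differ from each other, modestly but beyond the scatter, with a 3.0-fold lower number from compound 1 to compound 3 (0.48 log units; beyond the scatter).

The three compounds do not show whether a halogen is required for the low numbers or whether the 4-ethylphenyl of compound 2 is simply poor at this place, and an unsubstituted phenyl would separate these two readings. As far as these compounds go, how this place responds to a phenyl carrying an amine or a carboxylic acid also remains open.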